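The source may report more compounds than this note shows. Statements on the series, on what has been measured and on what is new or still open speak of the compounds shown alone.

Measured so far in a functional assay on H266 cells (Homo sapiens) for cytotoxicity, read by resazurin assay, with a stated time of 72 h; on this read-out lower numbers stand for stronger inhibition and higher numbers for weaker inhibition:
compound 1 `COc1cc(/C=C/C(=O)OC(C)CCOc2no[n+]([O-])c2S(=O)(=O)c2ccccc2)ccc1O`: 430 nM
compound 2 `O=C(/C=C/c1ccc(OCCCCCO[N+](=O)[O-])c(O)c1)OCCCCCO[N+](=O)[O-]`: > 50000 nM
compound 3 `COc1cc(/C=C/C(=O)OC/C=C/CO[N+](=O)[O-])ccc1O`: 9790 nM

Compound 3 stands highest of the two numbers given in this assay; the nearest number, that of compound 1, is lower by a gap beyond the scatter. Compound 2 gives only a limit of the assay, as shown in the limit of > 50000 nM in this assay, at which 1 of the 3 values shown sits.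

Compound 4 `COc1cc(/C=C/C(=O)OCCCO[N+](=O)[O-])ccc1O` differs from compound 3 by a group of 6 heavy atoms (2 carbon, 1 nitrogen, 3 oxygen; no ring) in place of a group of 7 heavy atoms (3 carbon, 1 nitrogen, 3 oxygen; no ring), on a saturated chain carbon bound to an oxygen next to a carbonyl group. Among the measured compounds shown here, no step between measured compounds is available to size this change. Compound 3 gives 9790 nM and compound 1 gives 430 nM, and compound 4 keeps the nitrate ester on a shortened chain, so the step in this assay is expected to stay within the scatter, in no clear direction. Compound 4 is expected near 12000 nM, with a range from 4000 nM to 40000 nM. The expected step is a 1.2-fold higher number from compound 3 to compound 4 (0.09 log units; within the scatter).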

Compound 4, half-maximal inhibitory concentration: 44000 nM
For compound 4 the middle estimate is 3.7-fold (0.56 log units) below the measured one; the measured number lies above the stated range.
By their numbers in this assay, from the lowest: compound 1; then compound 3; then compound 4. At a limit, above all of these: compound 2.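

In this assay, among the compounds shown here, the replacement of the group of 7 heavy atoms by 2-(nitrooxy)ethyl gives the first sized step at this position, a saturated chain carbon bound to an oxygen next to a carbonyl group: a 4.5-fold higher number from compound 3 to compound 4 (0.65 log units; beyond the scatter). The change is therefore not neutral here, and the number moves up with the shorter group. Nothing shown bears on what drives this step.

Going by these compounds, the step changes the heavy-atom count and the double bonds together, so their shares remain open. A saturated chain with the same count as the group that leaves, or a longer chain, would separate them.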